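A few compounds are considered here, and "the series" means these few. Any claim that something is new, unique, unknown or untested is made for them only; others in the source may bear on it.

Measured in a functional assay on XF498 cells (Homo sapiens) for cytotoxicity; on this read-out higher numbers stand for weaker inhibition and lower numbers for stronger inhibition:

- Compound 1 `Cc1nn(C)c(-n2ccc3ccccc32)c1/C=N/OCc1ccc(C(=O)OC(C)(C)C)cc1` gives 1.61 ug/mL
- Compound 2 `Cc1nn(C)c(N2CCCC2)c1/C=N/OCc1ccc(C(=O)OC(C)(C)C)cc1` gives 0.12 ug/mL
- Compound 3 `Cc1nn(C)c(-n2ccnc2)c1/C=N/OCc1ccc(C(=O)OC(C)(C)C)cc1` gives 8.15 ug/mL

These three compounds differ only in one group on the shared core. Compound 3 has the highest number of the three, which makes it the weakest inhibitor of the set in this assay. The next compound to consider is compound 4 `Cc1nn(C)c(-n2cccn2)c1/C=N/OCc1ccc(C(=O)OC(C)(C)C)cc1`, which has the same atoms as compound 3, joined differently: 1H-pyrazol-1-yl in place of 1H-imidazol-1-yl on an aromatic carbon. In words, this is 1H-pyrazol-1-yl in place of 1H-imidazol-1-yl on an aromatic carbon.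

Within the data shown here, no measured step makes this exact swap, so the evidence is indirect. Three steps at the same place show how much the number can move: a 5.1-fold higher number from compound 1 to compound 3 (0.70 log units; beyond the scatter), a 68-fold higher number from compound 2 to compound 3 (1.83 log units; beyond the scatter) and a 13-fold lower number from compound 1 to compound 2 (1.13 log units; beyond the scatter). The group here clearly matters, yet three compounds cannot show how two such closely related groups will compare. Compound 3 sits at the top of the measured range with 8.15 ug/mL, so a move down seems somewhat likelier than a move up, though a small change remains possible. The expectation is a modest step, and the estimate is a 2.3-fold lower number from compound 3 to compound 4 (0.37 log units; beyond the scatter). For compound 4 the estimated value is 3.5 ug/mL, with an expected range from 0.8 ug/mL to 14 ug/mL.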

Compound 4, half-maximal inhibitory concentration: 5.51 ug/mL
For compound 4 the middle estimate is 1.6-fold (0.20 log units) below the measured one, and the stated range covers the measured number.
By their numbers in this assay, from the lowest: compound 2; then compound 1; then compounds 4 and 3 (each within the scatter of the next).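

In this assay, 1H-pyrazol-1-yl and 1H-imidazol-1-yl, two groups with the same atoms joined differently, give a 1.5-fold lower number from compound 3 to compound 4 (0.17 log units; within the scatter) and so cannot be told apart at this position. Among these compounds, the wider picture from the earlier compounds holds with this new group in place: pyrrolidin-1-yl stands well apart, with a 46-fold higher number from compound 2 to compound 4 (1.66 log units; beyond the scatter) as the change, and 1H-indol-1-yl stands apart by less, with a 3.4-fold higher number from compound 1 to compound 4 (0.53 log units; beyond the scatter) as the change. Nothing shown here explains why the two isomeric groups read alike or why pyrrolidin-1-yl gives the lowest number.

Among the compounds shown here, with only one saturated amine group in the set, it remains open whether the low number of compound 2 would carry over to piperidin-1-yl, morpholin-4-yl or an open-chain dimethylamino group. From the compounds shown here alone, it is also open whether the order of these groups would stay the same if a free carboxylic acid replaced the tert-butyl ester at the far end of the molecule.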